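Bromo for Methoxy on an Inactive Amide Series

The compounds below may be only part of what the source reports. "The series", "measured", "known", "first", "only" and "open" are said of these compounds alone.

Three members of one amide series have been tested in a functional assay on A549 cells (Homo sapiens) for cytotoxicity, read by MTT assay, with a stated time of 72 h (a lower number here means a stronger inhibitor, a higher number a weaker inhibitor), and none of them shows measurable potency. Compound 3 `COc1ccc(-n2ccc(=O)c(C(=O)Nc3ccc(Oc4ccnc5c4ccn5C)c(F)c3)n2)cc1` gives only a limit there, > 60000 nM, so its true value is not known beyond that bound. Compound 1 `O=C(Nc1ccc(Oc2ccnc3[nH]ccc23)c(F)c1)c1nn(-c2ccc(Br)cc2)ccc1=O` likewise returns a limit, > 60000 nM. Among the measured compounds shown here, compound 2 `Cn1ccc2c(Oc3ccc(NC(=O)c4nn(-c5ccc(Br)cc5)ccc4=O)cc3)ccnc21` is the one member with a number, 59400 nM, which sits right at the edge of what this assay can resolve. Compound 3 therefore stands at the limit, as does compound 1, with compound 2 essentially alongside them; this is summed up by the observation that (the limit of > 60000 nM in this assay, at which 2 of the 3 values shown sit).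

Compound 4 `Cn1ccc2c(Oc3ccc(NC(=O)c4nn(-c5ccc(Br)cc5)ccc4=O)cc3F)ccnc21` arises from compound 3 by a single change: bromo in place of methoxy on an aromatic carbon, so that the 4-methoxyphenyl of compound 3 becomes the 4-bromophenyl of compound 4. For the measured compounds named here, no measured pair in this set isolates that change, so the size of its effect cannot be read from the data. Since the two compounds already carrying bromo sit at or at the edge of the limit, the expectation is that the step that the limit leaves unreadable from compound 3 to compound 4 stays within the scatter and that compound 4 again fails to register. Compound 4 is accordingly estimated at 70000 nM, within a range of 40000 nM to 150000 nM, most likely reported only as a limit.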

Compound 4, half-maximal inhibitory concentration: > 60000 nM
Compound 4: only a limit was reported (the forecaster's own chance of this, stated with the estimate: 70%); the middle value does not contradict the limit.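

Bromo in place of methoxy on this aromatic carbon, para to a large group, brings no measurable potency in this assay: compound 4, with its 4-bromophenyl, returns a limit, as compound 3 did with its 4-methoxyphenyl. Compound 4 also carries both the fluoro of compound 3 and the methyl on the aromatic nitrogen, and for the fluoro in place of hydrogen the record reads a number no lower from compound 2 to compound 4 (the limit leaves the size open). None of the new steps can be read in size, because every one of them ends on a limit: the limit of > 60000 nM in this assay, at which 3 of the 4 values shown sit.

The compounds shown therefore leave open whether this position matters at all in this assay, since neither the 4-methoxyphenyl nor the 4-bromophenyl gives a number to compare. Going by these compounds, it also remains open whether an amine or a carboxylic acid on this aromatic carbon, in place of bromo or methoxy, would bring a compound of the series clear of the limit.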